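From 4-fluorophenyl to benzyl on a sulfur

A few compounds are considered here, and "the series" means these few. Any claim that something is new, unique, unknown or untested is made for them only; others in the source may bear on it.

Compound 1 `CC(C)=Cc1c(C)c(N)c(C)c2c1OC(C)(C)C2` measured at 300 nM
Compound 2 `Cc1c(C)c2c(c(C)c1N)CC(C)(CSc1ccc(F)cc1)O2` measured at 220 nM

In a functional assay (microsomes, liver) with Rattus norvegicus as the target (on this read-out lower numbers stand for stronger inhibition and higher numbers for weaker inhibition), compound 2 gives 220 nM and compound 1 gives 300 nM and these two numbers lie within the usual scatter of each other. Compound 2 thus stands level with compound 1 on the numbers available, although their structures differ in more than one place.

The next structure is compound 3 `Cc1c(C)c2c(c(C)c1N)CC(C)(CSCc1ccccc1)O2` which has benzyl in place of 4-fluorophenyl on a sulfur, whose other neighbour is a saturated chain carbon. The counted difference reads benzyl in place of 4-fluorophenyl on a sulfur and both groups hold one six-membered aromatic ring of carbon only.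

Among the compounds with values here, no measured pair here differs in one place, so no earlier step in this assay shows how large such a change might be. Within the data shown here, the only guide is that compound 1 at 300 nM and compound 2 at 220 nM sit within the scatter of each other. The estimated step of a 1.1-fold higher number from compound 2 to compound 3 (0.06 log units; within the scatter) is expected to stay within the scatter, with no firm direction. For compound 3 the estimated value is 250 nM with 100 nM to 600 nM as the expected range.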

Compound 3, half-maximal inhibitory concentration: 260 nM
Compound 3: the middle estimate sits 1.0-fold (0.02 log units) below what was measured, and the stated range covers the measured number.
By their numbers in this assay, from the lowest: compounds 2, 3 and 1 (each within the scatter of the next).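

Within the data shown here, the step of a 1.2-fold higher number from compound 2 to compound 3 (0.07 log units; within the scatter) is the first comparison in this assay between compounds that differ in one place. It shows that, on a sulfur whose other neighbour is a saturated chain carbon, benzyl can stand in place of 4-fluorophenyl with no difference that can be told from the scatter, even though a fluorine leaves and a seventh carbon enters while the heavy-atom count and the single six-membered aromatic ring of carbon only stay the same. Nothing available offers an explanation for this level result.

As far as these compounds go, both groups on this sulfur hold one aromatic ring of carbon only, so it remains open how the read-out would respond to a group of another kind there, such as an amine, a carboxylic acid or a longer saturated chain. From the compounds shown here alone, whether an oxygen in place of the sulfur, or a fluorine on the benzyl, would keep the read-out at the same level also remains open.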